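The source may report more compounds than this note shows. Statements on the series, on what has been measured and on what is new or still open speak of the compounds shown alone.

Measured compounds in a toxicity assay on HEK-293T cells (Homo sapiens) for cytotoxicity, read by CCK-8 assay, with a stated time of 48 h; on this read-out lower numbers stand for higher toxicity in this test and higher numbers for lower toxicity in this test:
- compound 1 `Cn1cc(SCc2nnc(SCc3ccccc3Cl)n2-c2c(Cl)cccc2Cl)c2ccccc21`: 49600 nM
- compound 2 `Cn1cc(SCc2nnc(SCc3cc(Cl)ccc3Cl)n2-c2c(Cl)cccc2Cl)c2ccccc21`: > 100000 nM

Compound 1 gives a measured number, whereas for compound 2 the read-out is only a limit of the assay, (the limit of > 100000 nM in this assay, at which 1 of the 2 values shown sits). Going by the values given here, the one measured step, an at least 2.0-fold higher number from compound 1 to compound 2 (0.30 log units; that floor lies within the scatter), therefore has a floor that lies within the scatter, and the pair gives no firm direction.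

Compound 3 `Cn1cc(SCc2nnc(SCc3cccc(Cl)c3F)n2-c2c(Cl)cccc2Cl)c2ccccc21` is not yet measured. It differs from compound 2 by 3-chloro-2-fluorophenyl in place of 2,5-dichlorophenyl on a saturated chain carbon bound to a sulfur. Among the compounds with values here, no measured step covers this exchange; the only related comparison is the step from compound 1 to compound 2, which itself is not resolved beyond the scatter. The expectation for compound 3 is therefore a number near the values of compound 1 and the limit of compound 2, with no step beyond the scatter from compound 2 to compound 3, an at least 1.1-fold lower number from compound 2 to compound 3 (0.07 log units; that floor lies within the scatter). Compound 3 is estimated at 85000 nM, within 35000 nM to 200000 nM.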

Compound 3, half-maximal cytotoxic concentration: > 100000 nM
Compound 3 gave a limit, no number; the forecaster's own chance of this, stated with the estimate: 50%; middle value at least 1.1-fold (0.07 log units) from the limit.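

In this assay compound 3, with 3-chloro-2-fluorophenyl on a saturated chain carbon bound to a sulfur, gives > 100000 nM, which is a limit and not a number. Compound 2 and compound 3 therefore share the same limit, a fluorine-bearing phenyl now sits there alongside the dichlorinated one, and the step between them cannot be read: the limit of > 100000 nM in this assay, at which 2 of the 3 values shown sit.

The exchange of 2-chlorophenyl for 3-chloro-2-fluorophenyl gives an at least 2.0-fold higher number from compound 1 to compound 3 (0.30 log units; that floor lies within the scatter), so this pair, like the pair of compound 1 and compound 2, fixes no direction.

As far as these compounds go, how far compound 2 and compound 3 lie past the limit stays open. Also open, from the compounds shown here alone, is whether an amine or a carboxylic acid on that phenyl ring would bring the read-out to a measured number.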